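The compounds below may be only part of what the source reports. "The series", "measured", "known", "first", "only" and "open" are said of these compounds alone.

Measured compounds: compound 1 `COc1ccc(F)c(C2=NOC(COc3ccc(-c4nnnn4-c4cc(OC)c(OC)c(OC)c4)cc3N)C2)c1` with 1510 nM, compound 2 `COc1ccc(C2=NOC(COc3ccc(-c4nnnn4-c4cc(OC)c(OC)c(OC)c4)cc3N)C2)cc1N` with 2080 nM, compound 3 `COc1cc(-n2nnnc2-c2ccc(OCC3CC(c4ccc(OC)c(OC)c4OC)=NO3)c(N)c2)cc(OC)c1OC` with 2030 nM, all in a functional assay on A549 cells (Homo sapiens) for cytotoxicity, read by MTT assay, with a stated time of 48 h; a lower number here means a stronger inhibitor, a higher number a weaker inhibitor.

Compound 3 sits among the three at a value that is within the usual scatter of both compound 1 and compound 2. Compound 4 `COc1cc(C2=NOC(COc3ccc(-c4nnnn4-c4cc(OC)c(OC)c(OC)c4)cc3N)C2)ccc1O` is not yet measured; it differs from compound 3 in one place: 4-hydroxy-3-methoxyphenyl in place of 2,3,4-trimethoxyphenyl on a carbon with a double bond to nitrogen. The earlier steps shown here at this same carbon bear on it: a 1.3-fold higher number from compound 1 to compound 3 (0.13 log units; within the scatter) and a 1.0-fold lower number from compound 2 to compound 3 (0.01 log units; within the scatter), neither beyond the scatter. On that basis no step beyond the scatter is expected, with a 1.1-fold lower number from compound 3 to compound 4 (0.03 log units; within the scatter) being the estimated change. Compound 4 is therefore expected to give about 1900 nM in this assay, with a likely range from 900 nM to 4000 nM.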

Compound 4, half-maximal inhibitory concentration: 2010 nM
For compound 4 the middle estimate is 1.1-fold (0.02 log units) below the measured one; the measured number falls inside the stated range.
By their numbers in this assay, from the lowest: compounds 1, 4, 3 and 2 (each within the scatter of the next).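

In this assay, 4-hydroxy-3-methoxyphenyl, with 1 hydrogen-bond donor, replaces 2,3,4-trimethoxyphenyl, with 0, and this gives a 1.0-fold lower number from compound 3 to compound 4 (0.00 log units; within the scatter). The steps of a 1.0-fold lower number from compound 2 to compound 4 (0.01 log units; within the scatter) and a 1.3-fold higher number from compound 1 to compound 4 (0.12 log units; within the scatter) also stay within the scatter, so a hydroxy group on the phenyl ring at this carbon separates compound 4 from none of the other three compounds. No supporting measurement bears on this result.

From the compounds shown here alone, whether a non-aromatic group on this carbon, such as cyclohexyl, or a phenyl ring carrying a carboxylic acid, would give a step beyond the scatter remains open.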